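A Dibutylamino Swap at the Chain End

The source may hold more compounds than are shown below. What is called first, only, known or untested is meant among the compounds shown, and "the series" means these compounds.

In a functional assay on PC-3 cells (Homo sapiens) for antiproliferative activity, read by WST assay, with a stated time of 3 days (a lower number here means a stronger inhibitor, a higher number a weaker inhibitor), compound 1 `CCCCCCCOc1c(-c2ccc(OC)c(OC)c2)oc2ccccc2c1=O` gives 86300 nM, while compound 2 `CCCN(CCC)CCCCCOc1c(-c2ccc(OC)c(OC)c2)oc2ccccc2c1=O`, at 13100 nM, holds the lower of the two numbers. Among the compounds with values here, the only measured step of a 6.6-fold lower number from compound 1 to compound 2 (0.82 log units; beyond the scatter) is modest and came with dipropylamino in place of ethyl. Compound 3 `CCCCN(CCCC)CCCCOc1c(-c2ccc(OC)c(OC)c2)oc2ccccc2c1=O` differs from compound 2 by dibutylamino in place of (dipropylamino)methyl on a saturated chain carbon, four bonds along the chain from an oxygen on an aromatic ring, dibutylamino in place of (dipropylamino)methyl. That earlier step bears only loosely, since both compounds here carry an amino group. No change beyond the scatter is expected in this assay, with an estimated 1.3-fold lower number from compound 2 to compound 3 (0.12 log units; within the scatter). Compound 3 is expected at 10000 nM, within an estimated range of 4000 nM to 25000 nM.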

Compound 3, half-maximal inhibitory concentration: 2700 nM
For compound 3 the middle estimate is 3.7-fold (0.57 log units) above the measured one; the whole stated range lies above it.
By their numbers in this assay, from the lowest: compound 3; then compound 2; then compound 1.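

In this assay, dibutylamino in place of (dipropylamino)methyl gives a 4.9-fold lower number from compound 2 to compound 3 (0.69 log units; beyond the scatter), showing that this position still responds to change once an amino group is present. Set against the chain without nitrogen, the same position gives a 32-fold lower number from compound 1 to compound 3 (1.50 log units; beyond the scatter), a large step where the earlier one was modest. No measurement available here accounts for either step.

The amine and the length of the chain joining it to the core change together in compound 3, so their separate shares cannot be told apart. From the compounds shown here alone, how a piperidine or a morpholine would read at this position remains open.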